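The source may hold more compounds than are shown below. What is called first, only, known or untested is meant among the compounds shown, and "the series" means these compounds.

Of the compounds shown here, two of one series have been measured in a functional assay on HT-29 cells (Homo sapiens) for cytotoxicity, read by MTT assay, with a stated time of 24 h; a higher number here means a weaker inhibitor, a lower number a stronger inhibitor. Compound 1 `Fc1cc(-c2nnc(C(NCc3ccccc3)c3ccc[nH]3)o2)c(Cl)cc1Cl` gives 20000 nM in this assay. Compound 2 `Cc1ccc(-c2nnc(C(NCc3ccccc3)c3ccc[nH]3)o2)cc1` carries a 4-methylphenyl on the shared core where compound 1 carries a 2,4-dichloro-5-fluorophenyl. In this assay compound 2 gives 249000 nM. Within the data shown here, compound 2 thus stands at the highest of the two numbers, and the single measured step, a 12-fold higher number from compound 1 to compound 2 (1.10 log units; beyond the scatter), is a large one.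

Compound 3 `Cc1cccc(-c2nnc(C(NCc3ccccc3)c3ccc[nH]3)o2)c1` is the next compound to be measured in this assay. Its difference from compound 2 is 3-methylphenyl in place of 4-methylphenyl on an aromatic carbon. Among the measured compounds shown here, no measured step shows what happens when a methyl is shifted from one position of the phenyl ring to another; the only step available exchanges a dichlorofluorophenyl for a methylphenyl, which is a change of a quite different kind, so it gives little guidance here. With two isomers that keep every atom and every group, a step of at most the usual scatter is expected, and the estimated step of a 1.0-fold higher number from compound 2 to compound 3 (0.00 log units; within the scatter) reflects that. Compound 3 is therefore expected to give about 250000 nM in this assay, with a likely range from 90000 nM to 700000 nM.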

Compound 3, half-maximal inhibitory concentration: 202000 nM
For compound 3 the middle estimate is 1.2-fold (0.09 log units) above the measured one, within the range that was stated.
By their numbers in this assay, from the lowest: compound 1; then compounds 3 and 2 (each within the scatter of the next).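

In this assay the shift of the methyl appears as a 1.2-fold lower number from compound 2 to compound 3 (0.09 log units; within the scatter) and so, on this aromatic carbon of the five-membered ring, the 3-methylphenyl and the 4-methylphenyl cannot be told apart. The comparison with the 2,4-dichloro-5-fluorophenyl group now has a second reading, a 10-fold higher number from compound 1 to compound 3 (1.00 log units; beyond the scatter) and this shows that the earlier gap is not tied to a single placement of the methyl: both methylphenyl isomers give clearly higher numbers than that halogenated group. Nothing available gives a reason for either the near-equality of the two isomers or their gap from the halogenated group.

The compounds shown leave open whether that gap goes with the chlorines, with the fluorine or with their pattern on the ring, as the 2,4-dichloro-5-fluorophenyl group differs from the methylphenyl groups in several atoms at once. They also leave open how a single chlorine, a single fluorine, an amine or a carboxylic acid would read in this assay in place of the methyl.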